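The compounds below may be only part of what the source reports. "The series", "measured", "known", "first", "only" and "open" are said of these compounds alone.

Compound 1 `CC[C@H](C)[C@H](N)CN(C(=O)[C@@H]1C[C@H]1c1ccccc1)c1ccc(-c2ccc(OC)cc2)cc1` gives 120 nM in a functional assay for agonist activity at G protein-coupled receptor 88 (Homo sapiens), read by HTRF and cAMP accumulation; a higher number here means that more compound is needed for the effect, a lower number that less compound is needed.
Compound 2 `CC[C@H](C)[C@H](N)CN(C(=O)[C@@H]1C[C@H]1c1ccccc1)c1ccc(-c2ccc(C(=O)N(C)C)cc2)cc1` gives 980 nM in this assay.

Of these two, compound 2 has the higher number, so more of it is needed for the effect. Going by the values given here, the only measured step is an 8.2-fold higher number from compound 1 to compound 2 (0.91 log units; beyond the scatter), which came from putting dimethylcarbamoyl in place of methoxy on an aromatic carbon.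

Compound 3 `CC[C@H](C)[C@H](N)CN(C(=O)[C@@H]1C[C@H]1c1ccccc1)c1ccc(-c2ccc(NC(C)=O)cc2)cc1` has not yet been measured. The change from compound 2 is acetamido in place of dimethylcarbamoyl on an aromatic carbon. Both groups carry a carbonyl on a nitrogen; the newcomer is one heavy atom smaller and brings a hydrogen-bond donor that neither the dimethylcarbamoyl nor the methoxy had, and it sits para to a large group as before.

Among the compounds with values here, only one step bears on this, and it tells how the dimethylcarbamoyl compares with methoxy, not with acetamido. The expectation is therefore cautious: a small move back toward the number of compound 1 is expected, a 2.0-fold lower number from compound 2 to compound 3 (0.29 log units; within the scatter), but a result within the scatter would not surprise. Compound 3 is estimated at 500 nM, within 150 nM to 1800 nM.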

Compound 3, half-maximal effective concentration: 5500 nM
The estimate for compound 3 lay 11-fold (1.04 log units) below the measured number; the whole stated range lies below it.
By their numbers in this assay, from the lowest: compound 1; then compound 2; then compound 3.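

In this assay, the position para to a large group does not treat two similar groups alike: acetamido in place of dimethylcarbamoyl, both with a carbonyl and a nitrogen, gives a 5.6-fold higher number from compound 2 to compound 3 (0.75 log units; beyond the scatter). Sharing these atoms is therefore no guarantee of a similar result here, and the way they are arranged on the aromatic ring can go with a clear change in the number. Acetamido in place of methoxy gives the largest step in this set, a 46-fold higher number from compound 1 to compound 3 (1.66 log units; beyond the scatter), and acetamido is the only one of the three groups with a hydrogen-bond donor, although this is a single observation and nothing shown here explains the rise.

An N-methylacetamido group, which keeps the acetamido atoms but replaces the amide hydrogen with a methyl, would help show whether that hydrogen tracks with the higher number. Going by these compounds, it also remains open where a hydroxyl, an amine or a primary carboxamide at this position would fall, and whether any group here could give a lower number than methoxy.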